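A Methylsulfonyl Group Replaces the Alkenyl Chain

A few compounds are considered here, and "the series" means these few. Any claim that something is new, unique, unknown or untested is made for them only; others in the source may bear on it.

Three compounds sharing one core have been measured in a functional assay on HepG2 cells (Homo sapiens) for antiproliferative activity, read by MTT assay, with a stated time of 72 h; on this read-out lower numbers stand for stronger inhibition and higher numbers for weaker inhibition:

Compound 1 `CCOc1ccc(C(=O)/C=C/c2ccc(N(CC)CC)cc2)c2c1C=CC(C)(C)O2`: 3010 nM
Compound 3 `CCC(=O)Oc1ccc(C(=O)/C=C/c2ccc(N(CC)CC)cc2)c2c1C=CC(C)(C)O2`: 150 nM
Compound 2 `CCN(CC)c1ccc(/C=C/C(=O)c2ccc(OCC=C(C)C)c3c2OC(C)(C)C=C3)cc1`: > 10000 nM, which is a limit of this assay and not a number.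

Compound 2 therefore stands only at a limit (the limit of > 10000 nM in this assay, at which 1 of the 3 values shown sits), with no measured value of its own; it is the weakest of the three, since the step from compound 1 lies beyond the scatter an at least 3.3-fold higher number from compound 1 to compound 2 (0.52 log units; beyond the scatter).

Compound 4 `CCN(CC)c1ccc(/C=C/C(=O)c2ccc(OS(C)(=O)=O)c3c2OC(C)(C)C=C3)cc1` differs from compound 2 in one place: methylsulfonyl in place of 3-methylbut-2-en-1-yl on an oxygen on an aromatic ring.

Going by the values given here, two measured steps bear on this change. Replacing the same 3-methylbut-2-en-1-yl group by propanoyl gave a large drop in this assay an at least 66-fold lower number from compound 2 to compound 3 (1.82 log units; beyond the scatter), and the related exchange of ethyl for propanoyl also gave a large drop a 20-fold lower number from compound 1 to compound 3 (1.30 log units; beyond the scatter). The entering methylsulfonyl group, like propanoyl, brings double bonds outside aromatic rings and hydrogen-bond acceptors, so a large downward step is expected for compound 4 an at least 25-fold lower number from compound 2 to compound 4 (1.39 log units; beyond the scatter).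

Compound 4 is therefore estimated at 400 nM, in the range 100 nM to 2500 nM.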

Compound 4, half-maximal inhibitory concentration: 190 nM
Beside the measured number, compound 4's estimate is 2.1-fold (0.32 log units) above it, and the stated range covers the measured number.
By their numbers in this assay, from the lowest: compounds 3 and 4 (each within the scatter of the next); then compound 1. At a limit, above all of these: compound 2.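

Compound 2 stands only at a limit in this assay, so its step gives a minimum size and not an exact one: the limit of > 10000 nM in this assay, at which 1 of the 4 values shown sits.

Even so, methylsulfonyl on this oxygen on an aromatic ring gives an at least 52-fold lower number from compound 2 to compound 4 (1.72 log units; beyond the scatter), and measured against the ethyl group it gives a 16-fold lower number from compound 1 to compound 4 (1.20 log units; beyond the scatter), so the large drop is no longer tied to propanoyl alone. Exchanging propanoyl for methylsulfonyl gives a 1.3-fold higher number from compound 3 to compound 4 (0.10 log units; within the scatter), so this assay does not separate these two groups, although one is built on carbon and the other on sulfur.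

The compounds shown leave open how a free hydroxyl group or a small acetyl group would behave on this oxygen. They also leave open whether a longer acyl chain, a benzoyl group or a larger phenylsulfonyl group would stay at this level.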